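The compounds below may be only part of what the source reports. "The series", "measured", "known", "first", "only" and "open" are said of these compounds alone.

Among the compounds with values here, compound 2, with the structure `O/N=C(\c1ccccc1)c1nc2ccccc2s1`, is one of two compounds measured in an ADME assay on CHO cells (Cricetulus griseus) for cytotoxicity; on this read-out higher numbers stand for weaker inhibition and lower numbers for stronger inhibition. In this assay compound 2 gives only a limit, > 100000 nM. Compound 1, the structure `O/N=C(\c1cnco1)c1nc2ccccc2s1`, gives only a limit as well, > 100000 nM. Within the data shown here, the single measured step, a step that the two limits leave unreadable from compound 1 to compound 2, is therefore not readable in size, and the evidence amounts to the limit of > 100000 nM in this assay, at which 2 of the 2 values shown sit. Compound 3, the structure `O/N=C(/c1nc2ccccc2s1)C1CCCC1`, differs from compound 2 by cyclopentyl in place of phenyl on a carbon with a double bond to nitrogen. Among the measured compounds shown here, no measured step bears on an exchange of this kind, and the only step on record, from one limit to another, gives no direction. Compound 3 is thus expected to show no change beyond the scatter, a step that the limit leaves unreadable from compound 2 to compound 3, and most probably to return a limit again. The estimate for compound 3 in this assay is 150000 nM, within a range from 30000 nM to 1000000 nM.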

Compound 3, half-maximal inhibitory concentration: 83500 nM
Estimate against measurement, compound 3: 1.8-fold (0.25 log units) above; the measured number falls inside the stated range.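

Within the data shown here, compound 3 is the first compound in this assay to return a number rather than a limit, so a change on a carbon with a double bond to nitrogen can now be given a floor. Cyclopentyl in place of phenyl gives an at least 1.1-fold lower number from compound 2 to compound 3 (0.07 log units; that floor lies within the scatter), and cyclopentyl in place of 1,3-oxazol-5-yl gives an at least 1.1-fold lower number from compound 1 to compound 3 (0.07 log units; that floor lies within the scatter). Neither floor establishes a real change, and the remaining values are still limits: the limit of > 100000 nM in this assay, at which 2 of the 3 values shown sit.

Going by these compounds, the true size of both steps stays open, as does any ranking among the three groups. Also open, on these data alone, is whether a group of another kind at this place, such as an amine or a carboxylic acid, would give a number lower than that of compound 3 by more than the scatter.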